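Replacing the propargyloxy chain with 4-chlorophenyl on the sulfonamide

The source may report more compounds than this note shows. Statements on the series, on what has been measured and on what is new or still open speak of the compounds shown alone.

Measured compounds:
compound 1 `O=C1c2ccccc2N(Cc2ccccc2)S(=O)(=O)N1Cc1ccc(Cl)cc1` with 20000 nM
compound 2 `O=C(OCOCN1c2ccccc2C(=O)N(Cc2ccccc2)S1(=O)=O)c1ccccc1` with 110000 nM
compound 3 `C#CCOCN1c2ccccc2C(=O)N(Cc2ccccc2)S1(=O)=O` with 140000 nM

In a functional assay on HEL cells (Homo sapiens) (a higher number here means that more compound is tolerated, a lower number that less compound is tolerated), compound 3 holds the highest of the three numbers; compound 2 is nearest, the step of a 1.3-fold higher number from compound 2 to compound 3 (0.10 log units; within the scatter) being small, while compound 1, which gives 20000 nM, lies furthest and beyond the scatter. Compound 4 `O=C1c2ccccc2N(Cc2ccc(Cl)cc2)S(=O)(=O)N1Cc1ccccc1` differs from compound 3 by 4-chlorophenyl in place of propargyloxy on a saturated chain carbon bound to a sulfonamide nitrogen in a ring. Going by the values given here, the one measured step, a 1.3-fold higher number from compound 2 to compound 3 (0.10 log units; within the scatter), alters only the far end of that chain and does not touch this exchange. Compound 1, though, already carries a 4-chlorobenzyl group and gives 20000 nM, well under the value of compound 3. A lower number is therefore expected for compound 4, with a step of about a 5.6-fold lower number from compound 3 to compound 4 (0.75 log units; beyond the scatter). The estimate for compound 4 is 25000 nM, between 8000 nM and 80000 nM.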

Compound 4, minimum cytotoxic concentration: > 5000 nM
Compound 4 ended at the assay's limit (the forecaster's own chance of this, stated with the estimate: 5%); the middle value is on the limit's open side.
By their numbers in this assay, from the lowest: compound 1; then compounds 2 and 3 (each within the scatter of the next).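

In this assay, going by these compounds alone, compound 4 gives > 5000 nM, which is a limit of the assay and not a number, so no step from compound 3 to compound 4 can be read. On these data alone, whether 4-chlorobenzyl in place of (propargyloxy)methyl changes the number stays open.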